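The source may hold more compounds than are shown below. What is called first, only, known or untested is meant among the compounds shown, and "the series" means these compounds.

Measured in a functional assay on HeLa cells (Homo sapiens) for cytotoxicity, read by MTT assay, with a stated time of 48 h; a higher number here means a weaker inhibitor, a lower number a stronger inhibitor:
- compound 1 `COc1ccc(/C=C/c2cc(OC)c(OC)c(OC)c2-c2ccc(OC)c(OC)c2)cc1` gives 45000 nM
- compound 2 `COc1cc(/C=C/c2ccccc2)c(-c2ccccc2)c(OC)c1OC` gives 89000 nM
- compound 3 `C=C(c1ccccc1)c1cc(OC)c(OC)c(OC)c1-c1ccccc1` gives 42000 nM

Compound 3 lies within the scatter of compound 1 and under compound 2, so it shares the low end of this small set. Compound 4 `C=C(c1ccc(Cl)cc1)c1cc(OC)c(OC)c(OC)c1-c1ccccc1` has chloro in place of hydrogen on an aromatic carbon, turning 1-phenylethenyl into 1-(4-chlorophenyl)ethenyl: chloro in place of hydrogen on an aromatic carbon. Among the compounds with values here, the only measured step touching this group, a 2.1-fold lower number from compound 2 to compound 3 (0.33 log units; beyond the scatter), is modest and swaps 2-phenylethenyl for 1-phenylethenyl. Within the data shown here, no measured step tests a chloro group. In this assay a small move toward a lower number is therefore expected, probably not beyond the scatter. The estimated change is a 1.4-fold lower number from compound 3 to compound 4 (0.13 log units; within the scatter) as a working figure. Compound 4 is expected at 31000 nM, with an estimated range of 13000 nM to 75000 nM.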

Compound 4, half-maximal inhibitory concentration: 34000 nM
Compound 4: middle estimate off by 1.1-fold (0.04 log units), on the low side; the measured number falls inside the stated range.
By their numbers in this assay, from the lowest: compounds 4, 3, 1 and 2 (each within the scatter of the next, the first and the last beyond it).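

In this assay, within the data shown here, phenyl to 4-chlorophenyl, a change no earlier compound tested, gives a 1.2-fold lower number from compound 3 to compound 4 (0.09 log units; within the scatter) and so leaves the number effectively unchanged. The gap to the 2-phenylethenyl arrangement survives the added chloro, with a 2.6-fold lower number from compound 2 to compound 4 (0.42 log units; beyond the scatter) as a modest step. No measurement available here explains either step.

As far as these compounds go, how an amine or a carboxylic acid in place of chloro would read at this position stays open. Also open, from the compounds shown here alone, is whether chloro on the phenyl ring of compound 2 would give a similar step.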